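Cytotoxicity notes on a pyrrole carboxamide series

The source may report more compounds than this note shows. Statements on the series, on what has been measured and on what is new or still open speak of the compounds shown alone.

Compound 1 `CCn1c(C(=O)NCCCN(C)C)ccc1C(CC)(CC)c1ccc(OCC(=O)C(C)(C)C)c(C)c1` and compound 2 `CCn1c(C(=O)NCCCN(C)C)ccc1C(CC)(CC)c1ccc(OCC(O)C(C)(C)C)c(C)c1` share a core and differ only in 1-hydroxy-2,2-dimethylpropyl in place of (tert-butyl)carbonyl on a saturated chain carbon bound to an oxygen on an aromatic ring. In an ADME assay on L02 cells (Homo sapiens) for cytotoxicity, read by MTT assay, with a stated time of 48 h (on this read-out higher numbers stand for weaker inhibition and lower numbers for stronger inhibition), compound 1 gives 670 nM, and compound 2 gives 470 nM; the step is a 1.4-fold lower number from compound 1 to compound 2 (0.15 log units; within the scatter). Compound 3 `CC[C@@H](C)[C@H](NC(=O)c1ccc(C(CC)(CC)c2ccc(OCC(=O)C(C)(C)C)c(C)c2)n1CC)C(=O)O` carries a different amide substituent, the cores differing by 1-carboxy-2-methylbutyl in place of 3-(dimethylamino)propyl on an amide-type nitrogen; in this assay compound 3 gives 1500 nM, a step of a 2.2-fold higher number from compound 1 to compound 3 (0.35 log units; beyond the scatter).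

Compound 4 `CC[C@@H](C)[C@H](NC(=O)c1ccc(C(CC)(CC)c2ccc(OCC(O)C(C)(C)C)c(C)c2)n1CC)C(=O)O` relates to compound 3 as compound 2 relates to compound 1: the difference is 1-hydroxy-2,2-dimethylpropyl in place of (tert-butyl)carbonyl on a saturated chain carbon bound to an oxygen on an aromatic ring, at the same place as before, so this is the same change. Because the earlier change gave a 1.4-fold lower number from compound 1 to compound 2 (0.15 log units; within the scatter), a step of similar size is expected here, a 1.4-fold lower number from compound 3 to compound 4 (0.13 log units; within the scatter). For compound 4 the expected value in this assay is 1100 nM, estimated between 500 nM and 2500 nM.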

Compound 4, half-maximal inhibitory concentration: 1400 nM
Estimate against measurement, compound 4: 1.3-fold (0.10 log units) below, within the range that was stated.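

In this assay, 1-hydroxy-2,2-dimethylpropyl in place of (tert-butyl)carbonyl gives a 1.1-fold lower number from compound 3 to compound 4 (0.03 log units; within the scatter), and the small step carries over from one core to the other: the same change on two cores in this assay, a 1.4-fold lower number (0.15 log units; within the scatter) from compound 1 to compound 2 and a 1.1-fold lower number (0.03 log units; within the scatter) from compound 3 to compound 4, 1.3-fold (0.12 log units) apart, within the scatter of two such steps. 1-Carboxy-2-methylbutyl in place of 3-(dimethylamino)propyl on the amide-type nitrogen gives a 3.0-fold higher number from compound 2 to compound 4 (0.47 log units; beyond the scatter), and this step also carries over: the same change on two cores in this assay, a 2.2-fold higher number (0.35 log units; beyond the scatter) from compound 1 to compound 3 and a 3.0-fold higher number (0.47 log units; beyond the scatter) from compound 2 to compound 4, 1.3-fold (0.12 log units) apart, within the scatter of two such steps. This agreement rests on a single set of compounds in one cell assay; it does not show that either step would hold on other cores or in other assays, and it does not explain either step.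

Still open, as far as these compounds go, is how a longer chain ending in a dimethylamino group or an unbranched carboxylic acid on the amide-type nitrogen would behave in this assay. From the compounds shown here alone, a methyl ether in place of the hydroxyl of 1-hydroxy-2,2-dimethylpropyl is also open.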